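Two triple bonds replace an acetal on the amide

The compounds below may be only part of what the source reports. "The series", "measured", "known", "first", "only" and "open" are said of these compounds alone.

Compound 3 `CCn1c(C(=O)NCC(OC)OC)ccc1C(CC)(CC)c1ccc(OCC(O)C(C)(C)C)c(C)c1` gives 150 nM in an assay on HL-60 cells for agonist activity at vitamin D3 receptor (Homo sapiens), read by microscopy, with a stated time of 96 h (a lower number here means that less compound is needed, a higher number that more compound is needed for the effect), the second highest of three numbers; compound 1 `CCOC(=O)CN(C)C(=O)c1ccc(C(CC)(CC)c2ccc(OCC(O)C(C)(C)C)c(C)c2)n1CC` gives 210 nM and the gap a 1.4-fold lower number from compound 1 to compound 3 (0.15 log units; within the scatter) stays within the scatter, while compound 2 `CCn1c(C(=O)NCCCN(C)C)ccc1C(CC)(CC)c1ccc(OCC(O)C(C)(C)C)c(C)c1` gives 37 nM, with a 4.1-fold higher number from compound 2 to compound 3 (0.61 log units; beyond the scatter) beyond it. Compound 4 `CCn1c(C(=O)N(CCC#N)CCC#N)ccc1C(CC)(CC)c1ccc(OCC(O)C(C)(C)C)c(C)c1` carries a group of 9 heavy atoms (6 carbon, 3 nitrogen; no ring) in place of a group of 7 heavy atoms (4 carbon, 1 nitrogen, 2 oxygen; no ring), on a carbonyl carbon. The nearest guide is the exchange between compound 1 and compound 3, because a 1.4-fold lower number from compound 1 to compound 3 (0.15 log units; within the scatter) shows that swapping one such group for another hardly moved the number, whereas a 5.7-fold lower number from compound 1 to compound 2 (0.75 log units; beyond the scatter) shows the only large move came with the (3-(dimethylamino)propyl)amino group, which compound 4 does not carry. The expected step of a 1.3-fold higher number from compound 3 to compound 4 (0.12 log units; within the scatter) is therefore small. Compound 4 is estimated at 200 nM, between 80 nM and 500 nM.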

Compound 4, half-maximal effective concentration: 97 nM
Compound 4: the middle estimate sits 2.1-fold (0.31 log units) above what was measured; low and high end bracket the measured number.
By their numbers in this assay, from the lowest: compound 2; then compounds 4, 3 and 1 (each within the scatter of the next, the first and the last beyond it).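

With two triple bonds on the amide nitrogen, the group at this carbonyl carbon is larger and contains no oxygen, yet a 1.5-fold lower number from compound 3 to compound 4 (0.19 log units; within the scatter) stays within the scatter. A gap beyond the scatter does appear against the ester-bearing group, with a 2.2-fold lower number from compound 1 to compound 4 (0.34 log units; beyond the scatter). The nitrile chains still do not match the dimethylamino chain, given a 2.6-fold higher number from compound 2 to compound 4 (0.42 log units; beyond the scatter).

Nothing available explains any of these steps. Open, on these data alone, is what a single nitrile chain with the amide hydrogen kept would give, or a carboxylic acid in place of the nitriles.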